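The compounds below may be only part of what the source reports. "The series", "measured", "known", "first", "only" and "open" are said of these compounds alone.

Compound 1 `Cn1cc(-c2nc3c(-c4ccnc(OC5CC5)c4)cnn3cc2OCC(C)(C)O)cn1` was tested in an ADME assay on microsomes from liver (Homo sapiens) for metabolic stability, with a stated time of 60 min, tested at 1 uM (on this read-out lower numbers stand for a less stable compound and higher numbers for a more stable compound), where compound 1 gives 53%. Compound 2 `COc1cc(-c2cnn3cc(OC)c(C(C)C)nc23)ccn1` gives 40%, and compound 3 `COc1cc(-c2cnn3cc(OC)c(C)nc23)ccn1` gives 44%. Within the data shown here, the only single-site step measured, a number 4 percentage points higher from compound 2 to compound 3 (within the scatter), shows a change that stays within the scatter. Compound 1 has the highest of the three numbers: its gap to compound 3 lies within the scatter, its gap to compound 2 beyond it. Compound 4 `COc1cn2ncc(-c3ccnc(OC4CC4)c3)c2nc1-c1cnn(C)c1` differs from compound 1 by hydrogen in place of 1-hydroxy-1-methylethyl on a saturated chain carbon bound to an oxygen on an aromatic ring. Among the measured compounds shown here, no measured step covers this change; compounds 2 and 3 also carry methoxy in place of 2-hydroxy-2-methylpropoxy, but they differ from compound 1 at other places too, so their values only hint. A modest drop is therefore expected, a number 8 percentage points lower from compound 1 to compound 4 (within the scatter). Compound 4 is estimated at 45%, between 28% and 62%.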

Compound 4, percent of the compound remaining: 47%
Compound 4: middle estimate off by 2 percentage points, on the low side; the range from low to high includes it.
By their numbers in this assay, from the lowest: compounds 2, 3, 4 and 1 (each within the scatter of the next, the first and the last beyond it).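

Trimming 2-hydroxy-2-methylpropoxy to methoxy gives a number 6 percentage points lower from compound 1 to compound 4 (within the scatter) in this assay, the first direct reading of a change at this position. Removing 1-hydroxy-1-methylethyl, with its hydrogen-bond donor and acceptor, therefore leaves the result within the usual scatter for this read-out. No measurement at hand offers an explanation for this result.

Still open, on these data alone, is whether an amine, a carboxylic acid or a longer chain on this saturated chain carbon would shift the number beyond the scatter.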